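Thioether series: benzyl to phenoxyethyl on sulfur

The source may hold more compounds than are shown below. What is called first, only, known or untested is meant among the compounds shown, and "the series" means these compounds.

Working notes on the sulfur-linked pair measured so far. Compound 1 `Cn1c(=O)c2c(nc(Sc3ccccc3)n2C)n(C)c1=O` carries a phenyl directly on the sulfur; in an assay on isolated protein for inhibition of Amine oxidase [flavin-containing] A (Homo sapiens), read by fluorescence (on this read-out higher numbers stand for weaker inhibition and lower numbers for stronger inhibition), compound 1 gives 56400 nM. Compound 2 `Cn1c(=O)c2c(nc(SCc3ccccc3)n2C)n(C)c1=O` carries a benzyl on that sulfur, and in this assay compound 2 gives 8220 nM. Among the compounds with values here, the single measured step, a 6.9-fold lower number from compound 1 to compound 2 (0.84 log units; beyond the scatter), is the only comparison in hand. On the two numbers available compound 2 stands lowest, with compound 1 as its nearest neighbour at a clearly higher number.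

Compound 3 `Cn1c(=O)c2c(nc(SCCOc3ccccc3)n2C)n(C)c1=O` differs from compound 2 by phenoxymethyl in place of phenyl on a saturated chain carbon bound to a sulfur. Within the data shown here, the only measured step that bears on this is a 6.9-fold lower number from compound 1 to compound 2 (0.84 log units; beyond the scatter), where moving the phenyl off the sulfur onto a saturated carbon lowered the number. Among the measured compounds shown here, compound 3 carries the phenyl further out through a phenoxymethyl unit; no measured compound shows what a second such displacement does, so the direction is open. A step within the scatter, leaning towards a small further decrease, is expected in this assay. Compound 3 is therefore estimated at 6000 nM in this assay, with a range from 1500 nM to 24000 nM. The expected step is a 1.4-fold lower number from compound 2 to compound 3 (0.14 log units; within the scatter).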

Compound 3, half-maximal inhibitory concentration: 15500 nM
For compound 3 the middle estimate is 2.6-fold (0.41 log units) below the measured one; the measured number falls inside the stated range.
By their numbers in this assay, from the lowest: compounds 2 and 3 (each within the scatter of the next); then compound 1.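

In this assay, the step of a 1.9-fold higher number from compound 2 to compound 3 (0.28 log units; within the scatter) shows that, on a saturated chain carbon bound to a sulfur, phenoxymethyl in place of phenyl gives a reading that cannot be told apart from that of compound 2. This change brings in an oxygen and one hydrogen-bond acceptor, and neither addition moves the number beyond the scatter, whereas the earlier step of a 6.9-fold lower number from compound 1 to compound 2 (0.84 log units; beyond the scatter) lay beyond it; the lower number seen on going from phenyl to benzyl on the sulfur therefore does not extend to compound 3 as a further measurable drop. No available evidence bears on the origin of this flat result.

The compounds shown leave open whether the oxygen and the longer chain each have an effect of their own that cancels in compound 3, a question that a phenylpropyl group on the sulfur, with carbon in place of the oxygen, would address. Also open, going by these compounds, is how this position responds to a group of a different kind at the end of the chain, such as an amine or a carboxylic acid.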